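The compounds below may be only part of what the source reports. "The series", "measured", "known", "first", "only" and "open" are said of these compounds alone.

Measured compounds in an ADME assay on L02 cells (Homo sapiens) for cytotoxicity, read by MTT assay, with a stated time of 48 h; on this read-out lower numbers stand for stronger inhibition and higher numbers for weaker inhibition:

- compound 1 `CN1CCN(C[C@H]2CN(c3ccc(-n4cc(-c5ccccn5)cn4)c(F)c3)C(=O)O2)CC1` gives 70 ug/mL
- compound 2 `O=C1CNC(=O)N1C[C@H]1CN(c2ccc(-n3cc(-c4ccccn4)cn3)c(F)c2)C(=O)O1` gives > 400 ug/mL, a limit of the assay rather than a number
- compound 3 `CS(=O)(=O)NC[C@H]1CN(c2ccc(-n3cc(-c4ccccn4)cn3)c(F)c2)C(=O)O1` gives > 400 ug/mL, likewise a limit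

Compound 2 stands at the limit of > 400 ug/mL in this assay, at which 2 of the 3 values shown sit, so no number is available for it, only the limit. The change to compound 4 `CCNC(=O)NC[C@H]1CN(c2ccc(-n3cc(-c4ccccn4)cn3)c(F)c2)C(=O)O1` is (ethylcarbamoyl)amino in place of 2,5-dioxoimidazolidin-1-yl on a saturated chain carbon bound to a saturated ring carbon. Within the data shown here, no measured step starts from compound 2 and ends at a number: a step that the two limits leave unreadable from compound 2 to compound 3. The steps that reach compound 2 and compound 3 both start from compound 1: an at least 5.7-fold higher number from compound 1 to compound 2 (0.75 log units; beyond the scatter) and an at least 5.7-fold higher number from compound 1 to compound 3 (0.75 log units; beyond the scatter). Compound 4 shares with compound 2 and compound 3 the absence of the 4-methylpiperazin-1-yl of compound 1 on the saturated chain carbon bound to a saturated ring carbon, and the (ethylcarbamoyl)amino that enters carries no net charge, as the 2,5-dioxoimidazolidin-1-yl that leaves. The step of a number no higher from compound 2 to compound 4 (the limit leaves the size open) is therefore expected to be none beyond the scatter, with compound 4 expected to remain at or near the limit. The estimate for compound 4 in this assay is 400 ug/mL, with a range from 200 ug/mL to 800 ug/mL.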

Compound 4, half-maximal inhibitory concentration: > 400 ug/mL
Compound 4: a limit, no number (the forecaster's own chance of this, stated with the estimate: 75%); the middle value lies on the limit itself.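

In this assay compound 4 gives > 400 ug/mL, a limit of the assay and not a number. Replacing the 4-methylpiperazin-1-yl of compound 1 with (ethylcarbamoyl)amino gives an at least 5.7-fold higher number from compound 1 to compound 4 (0.75 log units; beyond the scatter), so a group with no ring and no net charge on the saturated chain carbon behaves here like the ring-bearing 2,5-dioxoimidazolidin-1-yl, and a ring in this group is not required to reach the limit. The steps among compound 2, compound 3 and compound 4 cannot be read, and only compound 1 gives a number: the limit of > 400 ug/mL in this assay, at which 3 of the 4 values shown sit.

Any order among compound 2, compound 3 and compound 4 remains open. Also open, as far as these compounds go, is whether a primary amine, a piperazin-1-yl without the methyl or a carboxylic acid on the same carbon would come down from the limit towards compound 1.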